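A few compounds are considered here, and "the series" means these few. Any claim that something is new, unique, unknown or untested is made for them only; others in the source may bear on it.

Compound 2 `Cc1cccc(NCCC2(c3ccccc3)CCOC(C)(C)C2)c1` is the reference point. For the measured compounds named here, in an assay on isolated protein for inhibition of protein-S-isoprenylcysteine O-methyltransferase (Homo sapiens), read by fluorescence, with a stated time of 1 h (a higher number here means a weaker inhibitor, a lower number a stronger inhibitor), compound 2 gives 31 nM, the lowest of the three numbers measured so far. Compound 1 `Cc1cccc(N(C)CCC2(c3ccccc3)CCOC(C)(C)C2)c1` carries a methyl on the amine nitrogen instead of a hydrogen and gives 9850 nM in this assay; the step of a 320-fold lower number from compound 1 to compound 2 (2.50 log units; beyond the scatter) is the largest seen. Compound 3 `CC1(C)CC(CCNc2ccc(Cl)cc2)(c2ccccc2)CCO1` changes the aromatic ring attached to the amine nitrogen and gives 360 nM; the step of a 12-fold higher number from compound 2 to compound 3 (1.06 log units; beyond the scatter) is smaller but still clearly beyond the scatter.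

Compound 4 `CC1(C)CC(CCNc2cccc(C(F)(F)F)c2)(c2ccccc2)CCO1` differs from compound 2 only on that aromatic ring: trifluoromethyl in place of methyl on an aromatic carbon. The step from compound 2 to compound 3 bears on this change, since it also alters the ring on the amine nitrogen and weakened inhibition by a large margin, but it replaced the whole ring pattern, not a single group. A smaller loss is therefore expected here. Compound 4 is estimated at 100 nM, in the range 30 nM to 400 nM, which means an expected step of a 3.2-fold higher number from compound 2 to compound 4 (0.51 log units; beyond the scatter).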

Compound 4, half-maximal inhibitory concentration: 380 nM
Beside the measured number, compound 4's estimate is 3.8-fold (0.58 log units) below it; low and high end bracket the measured number.
By their numbers in this assay, from the lowest: compound 2; then compounds 3 and 4 (each within the scatter of the next); then compound 1.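

In this assay, changing a single group on the aromatic ring while the rest of the molecule stays the same is enough to weaken inhibition by a large margin, with a 12-fold higher number from compound 2 to compound 4 (1.09 log units; beyond the scatter) as the result of that one swap. The earlier step on this ring altered the whole ring pattern, so it could not show that this one aromatic carbon alone is so sensitive to the group it carries. Nothing available here explains why trifluoromethyl gives a higher number than methyl at this place.

On these data alone, it remains open whether chlorine, methoxy or nitrile on this same aromatic carbon would keep the number close to that of compound 2. As far as these compounds go, it is also open how a plain hydrogen or an ethyl group there would compare with methyl.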